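Stretching the Alkyne: From Terminal Hydrogen to Octyl

The source may hold more compounds than are shown below. What is called first, only, known or untested is meant among the compounds shown, and "the series" means these compounds.

Three measured compounds share one core and differ only at a triple-bonded carbon. Compound 1 `CC(=O)Nc1nc(-c2cccc(NS(=O)(=O)c3ccc(C#CCO)cc3)c2)cs1` carries a hydroxymethyl there, and in a functional assay on A-375 cells (Homo sapiens) for antiproliferative activity, read by trypan blue exclusion, with a stated time of 48 h, tested at 5 uM (a lower number here means a stronger effect, a higher number a weaker effect of the compound at the concentration tested), compound 1 gives 99.3%. Compound 2 `CC(=O)Nc1nc(-c2cccc(NS(=O)(=O)c3ccc(C#C[Si](C)(C)C)cc3)c2)cs1` bears a silicon-containing group in that place, and in this assay compound 2 gives 4.2%. Compound 3 `C#Cc1ccc(S(=O)(=O)Nc2cccc(-c3csc(NC(C)=O)n3)c2)cc1` keeps only a hydrogen on that carbon; in this assay compound 3 gives 38.3%, the second highest of the three numbers, sitting between the other two. The change a number 61 percentage points lower from compound 1 to compound 3 (beyond the scatter) and the change a number 34.1 percentage points higher from compound 2 to compound 3 (beyond the scatter) are both large, so what sits on this carbon matters.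

Compound 4 `CCCCCCCCC#Cc1ccc(S(=O)(=O)Nc2cccc(-c3csc(NC(C)=O)n3)c2)cc1` differs from compound 3 by octyl in place of hydrogen on a triple-bonded carbon. The nearest guide is the silicon-bearing compound 2, where a larger group without donors or acceptors gave the lowest number, with a number 34.1 percentage points higher from compound 2 to compound 3 (beyond the scatter) as the size of that gap. The step of a number 23.3 percentage points lower from compound 3 to compound 4 (beyond the scatter) is therefore expected to be downward and large. For compound 4 a value of 15% is estimated, within a range from 3% to 45%.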

Compound 4, a percentage reported as activity, at one concentration (the size of the read-out at that concentration, not a potency): 8.9%
Beside the measured number, compound 4's estimate is 6.1 percentage points above it; the measured number falls inside the stated range.
By their numbers in this assay, from the lowest: compounds 2 and 4 (each within the scatter of the next); then compound 3; then compound 1.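

An all-carbon chain on this triple-bonded carbon also brings the number down: in this assay, octyl in place of hydrogen gives a number 29.4 percentage points lower from compound 3 to compound 4 (beyond the scatter), and heptyl in place of hydroxy on the saturated chain carbon gives a number 90.4 percentage points lower from compound 1 to compound 4 (beyond the scatter). Silicon is therefore not needed for a low number, since the octyl compound and the silicon-bearing compound cannot be told apart, with a number 4.7 percentage points higher from compound 2 to compound 4 (within the scatter). No measurement available here accounts for these differences.

On these data alone, it remains open how a shorter chain such as propyl or butyl would read, and whether a longer chain such as dodecyl would keep the number this low. Also open, as far as these compounds go, is what an amine or a carboxylic acid at the far end of the octyl chain would do.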